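Aryl amide variation in a growth-inactive series

The compounds below may be only part of what the source reports. "The series", "measured", "known", "first", "only" and "open" are said of these compounds alone.

Measured so far in an ADME assay on BaF3 cells (Mus musculus) for antiproliferative activity, read by CellTiter-Glo and CCK-8 assay, with a stated time of 72 h; on this read-out lower numbers stand for stronger inhibition of growth and higher numbers for weaker inhibition of growth:
Compound 1 `CNc1nc(Nc2ccc(C)c([N+](=O)[O-])c2)ncc1C(=O)Nc1cc(NC(=O)c2cccc(C(F)(F)F)c2)ccc1C`, a limit of the assay at > 10000 nM.
Compound 2 `CNc1nc(Nc2ccc(C)c([N+](=O)[O-])c2)ncc1C(=O)Nc1cc(NC(=O)c2ccc(OC)cc2)ccc1C`, likewise a limit of the assay at > 10000 nM.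

Compound 2 stands only at the assay limit, so the step that the two limits leave unreadable from compound 1 to compound 2 cannot be sized. Both values sit at the limit of > 10000 nM in this assay, at which 2 of the 2 values shown sit. Compound 3 `CNc1nc(Nc2ccc(C)c([N+](=O)[O-])c2)ncc1C(=O)Nc1cc(NC(=O)c2cc(OC)cc(OC)c2)ccc1C` differs from compound 2 by 3,5-dimethoxyphenyl in place of 4-methoxyphenyl on a carbonyl carbon. Among the compounds with values here, no measured step bears on this change with a readable size, and nothing suggests compound 3 would leave the limit. In this assay compound 3 is expected at 15000 nM, with a range from 5000 nM to 50000 nM. The step that the limit leaves unreadable from compound 2 to compound 3 is therefore expected to stay within the scatter.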

Compound 3, concentration for 50% growth inhibition: > 10000 nM
Compound 3 ended at the assay's limit; the forecaster's own chance of this, stated with the estimate: 85%; the middle value lies beyond the limit too.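

No step among compound 1, compound 2 and compound 3 can be read, as each value is a limit of the assay: the limit of > 10000 nM in this assay, at which 3 of the 3 values shown sit.

From the compounds shown here alone, whether any aryl group on this carbonyl carbon brings growth inhibition into the measurable range remains open.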